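From 3-chloropropyl to (carboxymethyl)carbamoyl on the shared core

A few compounds are considered here, and "the series" means these few. Any claim that something is new, unique, unknown or untested is made for them only; others in the source may bear on it.

Measured so far in a functional assay on MCF7 cells (Homo sapiens) for inhibition, read by radiometric assay and XTT assay; on this read-out higher numbers stand for weaker inhibition and lower numbers for stronger inhibition
compound 1 `CC/C=C/C=C/[C@@]1(C)SC(O)=CC1=O` gives > 80 ug/mL
compound 2 `CCCCCC[C@@]1(C)SC(=O)C=C1OCCCCCl` gives 20.8 ug/mL
compound 3 `C=CCC1(CC=C)C(=O)S[C@](C)(CCCCCCCC)C1=O` gives 40.5 ug/mL

Compound 1 reads > 80 ug/mL as a limit and not a number. In this assay compound 2 gives 20.8 ug/mL and compound 3 gives 40.5 ug/mL and these two numbers lie within the usual scatter of each other.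

Still unmeasured is compound 4 `CCCCCC[C@@]1(C)SC(=O)C=C1OCC(=O)NCC(=O)O` and the change from compound 2 is (carboxymethyl)carbamoyl in place of 3-chloropropyl on a saturated chain carbon bound to an oxygen on an unsaturated carbon with (carboxymethyl)carbamoyl in place of 3-chloropropyl on a saturated chain carbon bound to an oxygen on an unsaturated carbon.

For the measured compounds named here, no measured pair differs in one place only, so this step has no direct precedent. Neither compound 2 at 20.8 ug/mL nor compound 3 at 40.5 ug/mL carries the (carboxymethyl)carbamoyl, and nothing measured points to a gain from it. The expectation therefore leans towards weaker inhibition, and a report that is only a limit remains a real possibility. The expected move is a 2.2-fold higher number from compound 2 to compound 4 (0.34 log units; beyond the scatter) towards weaker inhibition and this estimate is a loose one. In this assay the estimated value for compound 4 is 45 ug/mL with an expected range from 15 ug/mL to 100 ug/mL at this stage.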

Compound 4, half-maximal inhibitory concentration: > 80 ug/mL
Compound 4 ended at the assay's limit; the forecaster's own chance of this, stated with the estimate: 35%; middle value at least 1.7-fold (0.24 log units) from the limit.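

In this assay, for the compounds shown here, (carboxymethyl)carbamoyl in place of 3-chloropropyl on a saturated chain carbon bound to an oxygen on an unsaturated carbon gives an at least 3.8-fold higher number from compound 2 to compound 4 (0.58 log units; beyond the scatter), the only step so far that changes a single place, and it shows that the read-out at this position depends on the group carried there. Compound 4 gives > 80 ug/mL, which is a limit of the assay and not a number. The step therefore fixes a direction, towards weaker inhibition, and only a lower bound on its size, with no upper bound on the loss: the limit of > 80 ug/mL in this assay, at which 2 of the 4 values shown sit.

The change swaps the whole group in one move, so the compounds shown do not tell whether the carboxylic acid, the amide or the loss of the chlorine accounts for the step. A methyl ester or a primary amide at the same place would separate the first two, and a plain propyl chain would show what the chlorine of compound 2 contributes in this assay.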